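A few compounds are considered here, and "the series" means these few. Any claim that something is new, unique, unknown or untested is made for them only; others in the source may bear on it.

Among the compounds with values here, in an ADME assay on CEM-SS cells (Homo sapiens) for cytotoxicity, read by XTT assay, with a stated time of 6 days (on this read-out higher numbers stand for lower toxicity in this test and lower numbers for higher toxicity in this test), the three compounds measured so far share one core. Compound 1 (`CCCC(=O)OCSc1ccccc1C(=O)NCCC(N)=O`) gives only a limit of the assay, > 100 uM, and no number. Compound 2 (`CCCC(=O)OCSc1ccccc1C(=O)NCCCCCCNC(C)=O`) gives 8 uM and compound 3 (`CCCC(=O)OCSc1ccccc1C(=O)NCC(=O)OC`) gives 27.3 uM, the higher of the two true numbers. Compound 4 (`CCCCCNC(=O)CNC(=O)c1ccccc1SCOC(=O)CCC`) carries pentylamino in place of methoxy on a carbonyl carbon. The closest guide is the modest 3.4-fold higher number from compound 2 to compound 3 (0.53 log units; beyond the scatter), since compound 2 alone holds a long chain; the large at least 12-fold lower number from compound 1 to compound 2 (1.09 log units; beyond the scatter) and the at least modest an at least 3.6-fold lower number from compound 1 to compound 3 (0.56 log units; beyond the scatter) also bear on it. A modest fall is therefore expected, a 2.1-fold lower number from compound 3 to compound 4 (0.32 log units; beyond the scatter), in this assay. Compound 4 is estimated at 13 uM, within an expected range of 5 uM to 35 uM.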

Compound 4, half-maximal toxic concentration: 24.8 uM
Beside the measured number, compound 4's estimate is 1.9-fold (0.28 log units) below it; measured number inside the range.
By their numbers in this assay, from the lowest: compound 2; then compounds 4 and 3 (each within the scatter of the next). At a limit, above all of these: compound 1.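

In this assay, pentylamino in place of methoxy on a carbonyl carbon gives a 1.1-fold lower number from compound 3 to compound 4 (0.04 log units; within the scatter), so compound 3 and compound 4 cannot be told apart at this position. A pentyl chain here does not by itself match the number of compound 2, as shown by a 3.1-fold higher number from compound 2 to compound 4 (0.49 log units; beyond the scatter). The remaining comparison, an at least 4.0-fold lower number from compound 1 to compound 4 (0.60 log units; beyond the scatter), starts from a limit and not a number: the limit of > 100 uM in this assay, at which 1 of the 4 values shown sits.

From the compounds shown here alone, whether hydroxy, a cyclic amine or a chain longer than pentylamino on this carbonyl carbon would give a similar number remains open.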